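The compounds below may be only part of what the source reports. "The series", "measured", "known", "first", "only" and "open" are said of these compounds alone.

In an ADME assay for pharmacokinetics, read by LC-MS, in phosphate buffer, with a stated time of 120 min, at pH 7.4, tested at 1 uM, in the presence of a further agent that is not named here (on this read-out lower numbers stand for a shorter-lived compound and higher numbers for a longer-lived compound), the measured compounds stand as follows:
Compound 1 `O=C(/C=C/C(F)(F)F)Nc1ccccc1`: 0.267 h
Compound 2 `O=C(O)C/C=C/C(=O)Nc1ccccc1`: > 8.53 h

Compound 2 gives > 8.53 h as a limit and not a number, so it stands only at the limit of > 8.53 h in this assay, at which 1 of the 2 values shown sits, for now. Compound 3 `O=C(/C=C/CC(=O)Nc1ccccc1)Nc1ccccc1` differs from it by anilino in place of hydroxy on a carbonyl carbon in the form of anilino in place of hydroxy on a carbonyl carbon. Among the compounds with values here, the one measured step of an at least 31-fold higher number from compound 1 to compound 2 (1.50 log units; beyond the scatter) was large but replaced trifluoromethyl elsewhere, and it bears only indirectly. Compound 3 has no trifluoromethyl, so a moderate fall at most is expected. The estimated change is an at least 1.7-fold lower number from compound 2 to compound 3 (0.23 log units; that floor lies within the scatter) and may partly hide behind the limit. Compound 3 is estimated at 5 h (expected range 1.5 h to 16 h).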

Compound 3, half-life: > 8.53 h
Compound 3 ended at the assay's limit (the forecaster's own chance of this, stated with the estimate: 30%); at least 1.7-fold (0.23 log units) between middle value and limit.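

In this assay compound 3 gives > 8.53 h, a limit and not a number, as compound 2 also does, so no step between compound 2 and compound 3 can be read: the limit of > 8.53 h in this assay, at which 2 of the 3 values shown sit.

As far as these compounds go, whether anilino in place of hydroxy on a carbonyl carbon changes the half-life at all stays open.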